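The source may hold more compounds than are shown below. What is called first, only, known or untested is meant among the compounds shown, and "the series" means these compounds.

Of the compounds shown here, three have been measured in a functional assay on Ehrlich cells (Mus musculus) for cytotoxicity, read by LDH release, with a stated time of 48 h (a higher number here means a weaker inhibitor, a lower number a stronger inhibitor), and they lie close together. Compound 1 (`Cc1cc(C(=O)c2ccccc2)ccc1OCC(=O)Nc1nc(-c2ccccc2)cs1`) gives 24500 nM there, compound 2 (`COc1ccc(-c2csc(NC(=O)COc3ccc(C(=O)c4ccccc4)cc3C)n2)cc1`) gives 28600 nM and compound 3 (`Cc1cc(C(=O)c2ccccc2)cc(C)c1OCC(=O)Nc1nc(-c2ccccc2)cs1`) gives 23400 nM on the same read-out. These numbers lie within the scatter of one another, so compound 3 stands level with the other two and no order among the three can be read.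

Compound 4 (`COc1ccc(-c2csc(NC(=O)COc3c(C)cc(C(=O)c4ccccc4)cc3C)n2)cc1`) has not yet been measured. It differs from compound 3 by methoxy in place of hydrogen on an aromatic carbon, which is the change from phenyl to 4-methoxyphenyl. The same change has been measured once, and it gave a 1.2-fold higher number from compound 1 to compound 2 (0.07 log units; within the scatter) without leaving the scatter. The methyl in place of hydrogen on an aromatic carbon gave a 1.0-fold lower number from compound 1 to compound 3 (0.02 log units; within the scatter) and also stays within the scatter. Resting on these two small steps, no step beyond the scatter is expected in this assay for the new compound, and no direction can be relied on. Among the compounds with values here, the estimated step is a 1.2-fold higher number from compound 3 to compound 4 (0.06 log units; within the scatter) and it follows the single methoxy example. Compound 4 is expected at 27000 nM with an estimated range from 17000 nM to 42000 nM in this measurement.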

Compound 4, half-maximal inhibitory concentration: 41500 nM
The estimate for compound 4 lay 1.5-fold (0.19 log units) below the measured number; low and high end bracket the measured number.
By their numbers in this assay, from the lowest: compounds 3, 1, 2 and 4 (each within the scatter of the next).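

In this assay, the methoxy in place of hydrogen, para to a large group, gave a 1.8-fold higher number from compound 3 to compound 4 (0.25 log units; within the scatter), so the change from phenyl to 4-methoxyphenyl now has a second reading, on a core carrying one more methyl, and it again stays within the scatter: the same change on two cores in this assay, a 1.2-fold higher number (0.07 log units; within the scatter) from compound 1 to compound 2 and a 1.8-fold higher number (0.25 log units; within the scatter) from compound 3 to compound 4, 1.5-fold (0.18 log units) apart, within the scatter of two such steps The methyl in place of hydrogen also gains a second reading, now with the 4-methoxyphenyl group in place, as a 1.5-fold higher number from compound 2 to compound 4 (0.16 log units; within the scatter), and this too stays within the scatter: the same change on two cores in this assay, a 1.0-fold lower number (0.02 log units; within the scatter) from compound 1 to compound 3 and a 1.5-fold higher number (0.16 log units; within the scatter) from compound 2 to compound 4, 1.5-fold (0.18 log units) apart, within the scatter of two such steps Each change has now been read on two cores without leaving the scatter, so neither a direction for either change nor any dependence of one change on the other can be relied on.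

The compounds shown leave open whether an amine or a carboxylic acid on this same aromatic carbon would give a step beyond the scatter. They also leave open whether a longer chain, such as ethoxy or butoxy, would read like methoxy here.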